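Trading an Aryl Ether for a Fluorophenyl Thioether

A few compounds are considered here, and "the series" means these few. Any claim that something is new, unique, unknown or untested is made for them only; others in the source may bear on it.

Measured compounds in a functional assay on SK-MEL-5 cells (Homo sapiens) for inhibition, read by sulforhodamine B assay, with a stated time of 48 h; on this read-out lower numbers stand for higher toxicity in this test and higher numbers for lower toxicity in this test:
Compound 1 `Nc1cc(N)c2nc(-c3ccccc3)c(Oc3ccc(Cl)c(Cl)c3)nc2c1` gives 83200 nM
Compound 2 `Nc1cc(N)c2nc(-c3ccccc3)c(NCc3ccc(Cl)c(Cl)c3)nc2c1` gives 34700 nM
Compound 3 `CCOC(=O)[C@H](CCC(=O)O)NC(=O)c1ccc(Sc2nc3cc(N)cc(N)c3nc2-c2ccccc2)cc1` gives 85100 nM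

Compound 1 stands second highest of these three numbers. Compound 3 sits within the scatter of compound 1, while compound 2 lies beyond the scatter with a lower number. Compound 4 `Nc1cc(N)c2nc(-c3ccccc3)c(Sc3ccc(F)cc3)nc2c1` is not yet measured. It differs from compound 1 in one place: (4-fluorophenyl)sulfanyl in place of 3,4-dichlorophenoxy on an aromatic carbon. Compound 3, which also carries a sulfanyl link on the shared core, shows a number indistinguishable from compound 1, so no step beyond the scatter is expected in this assay for this change, in either direction. The estimate for compound 4 is 70000 nM, within 30000 nM to 160000 nM, meaning an expected step of a 1.2-fold lower number from compound 1 to compound 4 (0.08 log units; within the scatter).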

Compound 4, concentration lethal to 50% of the cells: 70800 nM
Estimate against measurement, compound 4: 1.0-fold (0.00 log units) below, and the stated range covers the measured number.
By their numbers in this assay, from the lowest: compound 2; then compounds 4, 1 and 3 (each within the scatter of the next).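

Putting (4-fluorophenyl)sulfanyl in place of 3,4-dichlorophenoxy on this aromatic carbon gives a 1.2-fold lower number from compound 1 to compound 4 (0.07 log units; within the scatter) in this assay, so this exchange leaves the number within the scatter. The linking atom and the ring's halogens change together here, so their separate contributions cannot be told apart, and they could either have little effect or offset each other. No supporting data bear on why the number holds. Still open, as far as these compounds go, is how a morpholine ring or a plain alkyl chain at this position would read, since both compounds compared here carry a halogenated phenyl ring.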